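Hydroxy in place of methyl: a small expected step

This account rests on a few compounds, and the source may have more. Where it says the series, first, only, none or still open, it means among the compounds named here.

In a functional assay on MCF7 cells (Homo sapiens) for inhibition, read by MTT assay, with a stated time of 72 h (on this read-out lower numbers stand for stronger inhibition and higher numbers for weaker inhibition), compound 3 `COc1cc(OC)c(OC)cc1/C=C/C(=O)c1ccc(C)cc1` gives 33000 nM. Compound 2 `COc1cc(OC)c(OC)cc1/C=C/C(=O)c1ccc(O)cc1O` gives 33800 nM, so these two compounds stand level. Compound 1 `COc1cc(OC)c(OC)cc1/C=C/C(=O)c1ccc(-c2c[nH]cn2)cc1` is reported only as a limit, > 150000 nM. Compound 4 `COc1cc(OC)c(OC)cc1/C=C/C(=O)c1ccc(O)cc1` has hydroxy in place of methyl on an aromatic carbon, para to a large group (hydroxy in place of methyl on an aromatic carbon), and the same difference reads 4-methylphenyl to 4-hydroxyphenyl.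

Among the measured compounds shown here, two measured steps bear on this change. The closer one involves the hydroxy-bearing compound 2, with a 1.0-fold lower number from compound 2 to compound 3 (0.01 log units; within the scatter), which lies within the scatter. The other replaces a different group at the same place and gives an at least 4.5-fold lower number from compound 1 to compound 3 (0.65 log units; beyond the scatter), so that site can respond to a change, although this step says little about hydroxy. No step beyond the scatter is therefore expected, and the estimated change is a 1.1-fold lower number from compound 3 to compound 4 (0.04 log units; within the scatter). Compound 4 is estimated at 30000 nM, with an expected range of 12000 nM to 75000 nM.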

Compound 4, half-maximal inhibitory concentration: 182000 nM
The estimate for compound 4 lay 6.1-fold (0.78 log units) below the measured number; measured number outside the range, above it.
By their numbers in this assay, from the lowest: compounds 3 and 2 (each within the scatter of the next); then compound 4.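

In this assay the change gives a 5.5-fold higher number from compound 3 to compound 4 (0.74 log units; beyond the scatter) and so shows that this aromatic carbon responds to hydroxy in place of methyl, which the level standing of compound 2 and compound 3 had not revealed. Hydrogen in place of the other hydroxy gives a 5.4-fold higher number from compound 2 to compound 4 (0.73 log units; beyond the scatter) and so shows that the single hydroxy of compound 4 does not match the pair carried by compound 2. Compound 1 is reported only as a limit, > 150000 nM and its step to compound 4 cannot be read: the limit of > 150000 nM in this assay, at which 1 of the 4 values shown sits.

The compounds shown do not tell why hydroxy at this carbon gives the higher number. Going by these compounds, whether a methoxy or an amine at the same carbon would read like methyl or like hydroxy remains open.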